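Swapping the Benzyl Group on a Bis(trifluoromethyl) Sulfonamide

The source may hold more compounds than are shown below. What is called first, only, known or untested is meant among the compounds shown, and "the series" means these compounds.

Compound 1 `O=S(=O)(NCCCNCc1ccccc1Cl)c1cc(C(F)(F)F)cc(C(F)(F)F)c1` belongs to a small set of three compounds sharing one core and tested in a functional assay on Capan-2 cells (Homo sapiens) for inhibition, read by MTT assay, with a stated time of 72 h; a higher number here means a weaker inhibitor of growth, a lower number a stronger inhibitor of growth. In this assay compound 1 gives 13000 nM, the highest of the three numbers. Compound 2 `O=S(=O)(NCCCNCc1ccc(Cl)c(Cl)c1)c1cc(C(F)(F)F)cc(C(F)(F)F)c1` gives 1800 nM, and compound 3 `O=S(=O)(NCCCNCc1ccc(-c2ccccc2)cc1)c1cc(C(F)(F)F)cc(C(F)(F)F)c1` gives 2200 nM. Among the measured compounds shown here, the only directly readable step is a 7.2-fold lower number from compound 1 to compound 2 (0.86 log units; beyond the scatter). Compound 3 has no single-point relation to compound 1, but its value lies close to that of compound 2, so both companions sit well below compound 1.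

The unmeasured compound 4 `COc1ccc(CNCCCNS(=O)(=O)c2cc(C(F)(F)F)cc(C(F)(F)F)c2)cc1` differs from compound 1 in one place: 4-methoxyphenyl in place of 2-chlorophenyl on a saturated chain carbon bound to an amine nitrogen. For the measured compounds named here, the step from compound 1 to compound 2 is the only measured step at this place, and it is a different substitution, so it bears on the new change only loosely. Going by the values given here, still, both measured replacements of 2-chlorophenyl at this place gave clearly lower numbers, which points toward a lower number for compound 4 as well, though probably a smaller move than the one seen for compound 2. Compound 4 is therefore expected to give about 4500 nM, within a range of 1500 nM to 12000 nM. The expected step is a 2.9-fold lower number from compound 1 to compound 4 (0.46 log units; beyond the scatter).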

Compound 4, concentration for 50% growth inhibition: 2400 nM
Compound 4: middle estimate off by 1.9-fold (0.27 log units), on the high side, within the range that was stated.
By their numbers in this assay, from the lowest: compounds 2, 3 and 4 (each within the scatter of the next); then compound 1.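

Compound 4 shows that the drop seen with compound 2 is not tied to chlorine on the ring: 4-methoxyphenyl in place of 2-chlorophenyl on a saturated chain carbon bound to an amine nitrogen gives a 5.4-fold lower number from compound 1 to compound 4 (0.73 log units; beyond the scatter) in this assay, even though the entering group carries no chlorine and has one hydrogen-bond acceptor where the leaving group has none. The new compound also cannot be told apart from its two companions, since methoxy in place of phenyl on an aromatic carbon gives a 1.1-fold higher number from compound 3 to compound 4 (0.04 log units; within the scatter) and 4-methoxyphenyl in place of 3,4-dichlorophenyl gives a 1.3-fold higher number from compound 2 to compound 4 (0.12 log units; within the scatter), which leaves compound 1 alone among the four and compounds 2, 3 and 4 together despite their quite different groups at this place. Nothing available here explains why these three groups read alike or why 2-chlorophenyl stands apart.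

The compounds shown leave open whether the number of compound 1 reflects something particular to 2-chlorophenyl or whether a plain benzyl group or a 4-chlorobenzyl group would read like compound 1 or like the other three. They also leave open how far this tolerance extends, for instance to a cyclohexylmethyl group with no aromatic ring at this place.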